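Swapping the Sulfonamide for a Cyanocyclopropyl Group

The source may report more compounds than this note shows. Statements on the series, on what has been measured and on what is new or still open speak of the compounds shown alone.

Measured so far in an assay on Sf9 cells for inhibition of serine/threonine-protein kinase 4 (Homo sapiens), read by luminescence and ADP-Glo, with a stated time of 1 h, in the presence of a further agent that is not named here; on this read-out lower numbers stand for stronger inhibition and higher numbers for weaker inhibition:
compound 1, `CCNS(=O)(=O)c1ccc(Nc2ncc3c(n2)N(C)C(c2ccccc2C)C(=O)N3C)cc1`: 119 nM
compound 2, `Cc1ccccc1C1C(=O)N(C)c2cnc(Nc3ccc(S(=O)(=O)NC4CC4)cc3)nc2N1C`: 53 nM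
compound 3, `Cc1ccccc1C1C(=O)N(C)c2cnc(Nc3ccc(S(=O)(=O)NCC4CC4)cc3)nc2N1C`: 60 nM

Compound 3 sits between the other two: a 2.0-fold lower number from compound 1 to compound 3 (0.30 log units; within the scatter) and a 1.1-fold higher number from compound 2 to compound 3 (0.05 log units; within the scatter), both within the scatter. Compound 4, `Cc1ccccc1C1C(=O)N(C)c2cnc(Nc3ccc(C4(C#N)CC4)cc3)nc2N1C`, differs from compound 3 by 1-cyanocyclopropyl in place of (cyclopropylmethyl)sulfamoyl on an aromatic carbon. Within the data shown here, none of the measured steps bears on this change; all three (a 2.2-fold lower number from compound 1 to compound 2 (0.35 log units; beyond the scatter), a 2.0-fold lower number from compound 1 to compound 3 (0.30 log units; within the scatter), a 1.1-fold higher number from compound 2 to compound 3 (0.05 log units; within the scatter)) vary only the group on the sulfonamide nitrogen, which compound 4 no longer carries. The expected size and direction of the step are therefore unknown, and a wide range is estimated. Compound 4 is expected to give 180 nM in this assay, with a range of 40 nM to 900 nM, an estimated step of a 3.0-fold higher number from compound 3 to compound 4 (0.48 log units; beyond the scatter).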

Compound 4, half-maximal inhibitory concentration: 256 nM
Compound 4: the middle estimate sits 1.4-fold (0.15 log units) below what was measured; the measured number falls inside the stated range.
By their numbers in this assay, from the lowest: compounds 2, 3 and 1 (each within the scatter of the next, the first and the last beyond it); then compound 4.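

Removing the sulfonamide from this aromatic carbon raises the number in this assay whichever sulfamoyl group leaves: with (cyclopropylmethyl)sulfamoyl (a 4.3-fold higher number from compound 3 to compound 4 (0.63 log units; beyond the scatter)), with cyclopropylsulfamoyl (a 4.8-fold higher number from compound 2 to compound 4 (0.68 log units; beyond the scatter)) and with ethylsulfamoyl (a 2.2-fold higher number from compound 1 to compound 4 (0.33 log units; beyond the scatter)). The earlier compounds shown here varied only the group on the sulfonamide nitrogen, whereas these steps show that 1-cyanocyclopropyl does not match any of the three sulfamoyl groups at this position.

The compounds shown leave open which part of the sulfamoyl group matters, and whether a methylsulfonyl group, a carboxylic acid or an amine here would restore the lower numbers. Nothing at hand explains the rise.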